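A few compounds are considered here, and "the series" means these few. Any claim that something is new, unique, unknown or untested is made for them only; others in the source may bear on it.

In an assay on CHO cells for displacement of a labelled ligand from adenosine receptor A3 (Homo sapiens), read by scintillation counting, tested at 10 uM (a higher number here means more inhibition at the concentration tested (going by the name of the read-out), a lower number less inhibition), compound 1 `Cc1csc(N)c1C(=O)c1ccc(Cl)cc1` gives 1%. Compound 2 `CC(C)(C)Cc1c(-c2ccccn2)sc(N)c1C(=O)c1ccc(Cl)cc1`, which carries a neopentyl group and a pyridin-2-yl group on the shared core, gives 1% in this assay, level with compound 1 within the scatter. Compound 3 `COc1ccccc1-c1sc(N)c(C(=O)c2ccc(Cl)cc2)c1CC(C)(C)C` differs from compound 2 in one place: 2-methoxyphenyl in place of pyridin-2-yl on an aromatic carbon. Going by the values given here, no step between measured compounds is available, so the effect of this change is open. The step of a number 2 percentage points higher from compound 2 to compound 3 (within the scatter) is expected to stay within the scatter because compound 2 gives 1%. Compound 3 is therefore estimated at 3%, in a range from -5% to 15%.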

Compound 3, a percentage reported as inhibition, at one concentration (the size of the read-out at that concentration, not a potency): 1%
Compound 3: middle estimate off by 2 percentage points, on the high side, within the range that was stated.
By their numbers in this assay, from the lowest: compounds 1, 2 and 3 (each within the scatter of the next).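

In this assay, going by these compounds alone, putting 2-methoxyphenyl in place of pyridin-2-yl on the aromatic carbon next to the ring sulfur gives no change at the digits printed from compound 2 to compound 3 (within the scatter) and is the first step read at this position. Exchanging this ring for one of carbon only, with two more heavy atoms, therefore brings no gain in inhibition at the concentration tested. Nothing available accounts for this result. As far as these compounds go, whether an amine or a carboxylic acid at this position would raise the value remains open. Also open, from the compounds shown here alone, is what a shorter chain in place of the neopentyl group would do.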